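Amide substituent swap on the shared core: compound 2 to compound 4

The source may hold more compounds than are shown below. What is called first, only, known or untested is meant among the compounds shown, and "the series" means these compounds.

Three amides of the shared core have been measured in a functional assay on Caco-2 cells (Homo sapiens) for antiproliferative activity, read by MTT assay, with a stated time of 48 h; on this read-out lower numbers stand for stronger inhibition and higher numbers for weaker inhibition. Compound 1 `C=CCN(C)C(=O)c1ccc(C(CC)(CC)c2ccc(OCCC(O)(CC)CC)c(C)c2)n1CC` gives in this assay only a limit, > 50000 nM. Compound 2 `CCn1c(C(=O)Nc2ccc(OC(F)(F)F)cc2)ccc1C(CC)(CC)c1ccc(OCCC(O)(CC)CC)c(C)c1` likewise gives only a limit in this assay, > 50000 nM. Within the data shown here, compound 3 `CCOC(=O)CN(C)C(=O)c1ccc(C(CC)(CC)c2ccc(OCCC(O)(CC)CC)c(C)c2)n1CC` is the one member with a number, 30300 nM. The step from compound 1 to compound 2 is a step that the two limits leave unreadable from compound 1 to compound 2. Among the measured compounds shown here, the step of an at least 1.6-fold lower number from compound 1 to compound 3 (0.21 log units; that floor lies within the scatter) and the step of an at least 1.6-fold lower number from compound 2 to compound 3 (0.21 log units; that floor lies within the scatter) each reach only the floor set by the limit of > 50000 nM in this assay, at which 2 of the 3 values shown sit, so no amide variation so far has moved the series beyond the scatter.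

Compound 4 `CCn1c(C(=O)NC(C)CO)ccc1C(CC)(CC)c1ccc(OCCC(O)(CC)CC)c(C)c1` is not yet measured. Its change from compound 2 is 1-(hydroxymethyl)ethyl in place of 4-(trifluoromethoxy)phenyl on an amide-type nitrogen. The step from compound 2 to compound 3, which also removes the 4-(trifluoromethoxy)phenyl from the carbonyl carbon, bears on it most directly, and it shows at most a shift within the scatter. For the measured compounds named here, the amide side chain of compound 4 therefore carries no measured precedent for a larger step in this assay, in either direction.

Compound 4 is expected to stay near the limit, 45000 nM, with a range from 15000 nM to 150000 nM. The step from compound 2 to compound 4 is estimated as an at least 1.1-fold lower number from compound 2 to compound 4 (0.04 log units; that floor lies within the scatter).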

Compound 4, half-maximal inhibitory concentration: > 50000 nM
Compound 4: no number, only a limit; the forecaster's own chance of this, stated with the estimate: 60%; at least 1.1-fold (0.04 log units) between middle value and limit.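

In this assay compound 4 gives only a limit of the assay, > 50000 nM, so 1-(hydroxymethyl)ethyl on the amide-type nitrogen, with no ring and with a hydrogen-bond donor that 4-(trifluoromethoxy)phenyl lacks, yields no number any more than the aromatic group did. The steps joining compound 4 to compound 1 and to compound 2 cannot be read, as both ends of each are limits. The only readable step is an at least 1.6-fold higher number from compound 3 to compound 4 (0.21 log units; that floor lies within the scatter), so the replacement of the aromatic group by this small open chain adds a second type of amide side chain without separating any pair of compounds in the series, and the comparison remains confined by the ceiling of the read-out: the limit of > 50000 nM in this assay, at which 3 of the 4 values shown sit.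

On these data alone, whether any group at this amide gives a value clearly separated from that ceiling remains open, and compound 3 alone offers a number to compare against. A carboxylic acid in place of the ethoxycarbonyl of compound 3, or a basic amine such as a dimethylamino group on a longer chain at the amide nitrogen, would test whether this position can move the read-out at all.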